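The source may report more compounds than this note shows. Statements on the series, on what has been measured and on what is new or still open speak of the compounds shown alone.

Two measured compounds share one core and differ only in the group on the carbonyl carbon. Compound 1 `COc1cc(-c2cc(/C=C/C(=O)c3ccc(N)cc3)[nH]n2)cc(OC)c1OC` carries a 4-aminophenyl there, and in a functional assay on NCI-H322M cells (Homo sapiens) for cytotoxicity, read by sulforhodamine B assay, with a stated time of 48 h, tested at 100 uM (on this read-out lower numbers stand for a stronger effect and higher numbers for a weaker effect at the one concentration tested), compound 1 gives -89%. Compound 2 `COc1ccc(C(=O)/C=C/c2cc(-c3cc(OC)c(OC)c(OC)c3)n[nH]2)cc1OC` carries a 3,4-dimethoxyphenyl instead, and in this assay compound 2 gives -90%. Among the compounds with values here, the only step between them, a number 1 percentage points lower from compound 1 to compound 2 (within the scatter), is within the scatter, so compound 2 stands alongside compound 1 rather than apart from it.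

Compound 3 `COc1cc(-c2cc(/C=C/C(=O)c3ccc(F)c(F)c3)[nH]n2)cc(OC)c1OC` is not yet measured. It differs from compound 2 in one place: 3,4-difluorophenyl in place of 3,4-dimethoxyphenyl on a carbonyl carbon. Within the data shown here, the single measured step that bears on this place is the one in which a number 1 percentage points lower from compound 1 to compound 2 (within the scatter), which did not move the read-out beyond the scatter even though the group was swapped wholesale. With only that to go on, a further swap of the group at the same place is expected to produce no step beyond the scatter in this assay. Compound 3 is therefore estimated at about -85%, with a range from -100% to -55%. This estimate corresponds to an expected step of a number 5 percentage points higher from compound 2 to compound 3 (within the scatter).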

Compound 3, a percentage reported as activity, at one concentration (the size of the read-out at that concentration, not a potency): 3%
Beside the measured number, compound 3's estimate is 88 percentage points below it; the measured number lies above the stated range.
By their numbers in this assay, from the lowest: compounds 2 and 1 (each within the scatter of the next); then compound 3.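

The group on the carbonyl carbon matters in this assay after all: there is a number 93 percentage points higher from compound 2 to compound 3 (beyond the scatter), and likewise a number 92 percentage points higher from compound 1 to compound 3 (beyond the scatter), both far beyond the scatter. The pair compound 1 and compound 2 alone made this place look tolerant of a change of group, whereas compound 3 shows that keeping the shared core and the six-membered aromatic carbon ring is not enough to hold the effect, since the 3,4-difluorophenyl group brings fluorine in place of the oxygen-bearing methoxy groups and takes the count of hydrogen-bond acceptors from 2 to 0. No measurement here explains why the read-out moves so far with this swap.

With three compounds, the loss cannot be tied to one feature of the group, and a 4-fluorophenyl, a 3,4-dichlorophenyl or a 3,4-dihydroxyphenyl group would each help separate the effect of the fluorine atoms from that of the missing methoxy groups. The read-out also comes from a single concentration, so how the potency of these compounds compares across a range of concentrations stays open.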